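The source may report more compounds than this note shows. Statements on the series, on what has been measured and on what is new or still open speak of the compounds shown alone.

Measured compounds:
compound 1 `COc1ccc(-c2nc3cccc(-c4cc(OC)c(OC)c(OC)c4)c3o2)cc1F` — 1700 nM
compound 2 `COc1cc(-c2cccc3nc(-c4ccc5cc[nH]c5c4)oc23)cc(OC)c1OC` — 300 nM
compound 3 `COc1cc(-c2cccc3nc(-c4ccco4)oc23)cc(OC)c1OC` — 10600 nM

In a functional assay on U-251 cells (Homo sapiens) for antiproliferative activity, read by MTT assay, with a stated time of 48 h (a higher number here means a weaker inhibitor, a lower number a stronger inhibitor), compound 1 holds the second highest of the three numbers, with compound 2 closer below it and compound 3 farther above it. Compound 4 `COc1cc(-c2cccc3nc(-c4cccs4)oc23)cc(OC)c1OC` differs from compound 1 in one place: thiophen-2-yl in place of 3-fluoro-4-methoxyphenyl on an aromatic carbon. The step that bears most on this change is a 6.2-fold higher number from compound 1 to compound 3 (0.79 log units; beyond the scatter), where another five-membered aromatic ring with 1 hetero atom took the same position; the opposite move, a 5.7-fold lower number from compound 1 to compound 2 (0.75 log units; beyond the scatter), went the other way. The step of a 3.5-fold higher number from compound 1 to compound 4 (0.55 log units; beyond the scatter) is therefore expected to be a weaker result. Compound 4 is estimated at 6000 nM, within 2000 nM to 20000 nM.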

Compound 4, half-maximal inhibitory concentration: 3000 nM
Estimate against measurement, compound 4: 2.0-fold (0.30 log units) above, within the range that was stated.
By their numbers in this assay, from the lowest: compound 2; then compounds 1 and 4 (each within the scatter of the next); then compound 3.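

At this carbon of the shared core, the two five-membered aromatic rings do not behave alike: thiophen-2-yl in place of furan-2-yl gives a 3.5-fold lower number from compound 3 to compound 4 (0.55 log units; beyond the scatter). Thiophen-2-yl in place of 3-fluoro-4-methoxyphenyl, with a 1.8-fold higher number from compound 1 to compound 4 (0.25 log units; within the scatter), gives no difference that can be told apart, whereas thiophen-2-yl in place of 1H-indol-6-yl gives a 10-fold higher number from compound 2 to compound 4 (1.00 log units; beyond the scatter). Nothing available explains these differences. The compounds shown leave open whether a thiazol-2-yl or pyrrol-2-yl ring would fall nearer thiophen-2-yl or furan-2-yl. They also leave open what an amine on the thiophen-2-yl ring would do.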